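A Hydroxyethyl Amide Variant of Compound 1

The compounds below may be only part of what the source reports. "The series", "measured", "known", "first", "only" and "open" are said of these compounds alone.

Compound 1, `COc1cc2c(cc1OC)C(CC(=O)N(C)C)CC2`: 22.6%
Compound 2, `CCNC(=O)CC1CCc2cc(OC)c(OC)cc21`: 23.6%
Compound 3, `COc1cc2c(cc1OC)C(CC(=O)NC1CCCCC1)CC2`: 44.7%

In a functional assay on the whole organism (strain Swiss albino) for inhibition, with Mus musculus as the target, in the writhing test, with stated times of 60 min and 15 min, at a dose of 100 mg/kg by the oral route (a higher number here means more inhibition at the dose given (going by the name of the read-out), a lower number less inhibition), compound 1 gives the lowest of the three numbers; compound 2 lies within the scatter of it, while compound 3 stands beyond it. Compound 4, `COc1cc2c(cc1OC)C(CC(=O)NCCO)CC2`, differs from compound 1 in one place: (2-hydroxyethyl)amino in place of dimethylamino on a carbonyl carbon. Two measured steps also alter the amide-type nitrogen of compound 1. The step of a number 1 percentage points higher from compound 1 to compound 2 (within the scatter) put an ethyl chain there and stayed within the scatter; the step of a number 22.1 percentage points higher from compound 1 to compound 3 (beyond the scatter) put a cyclohexyl ring there. The entering group of compound 4 is a chain without a ring, closer to the ethyl case, so only a step of about a number 4.4 percentage points higher from compound 1 to compound 4 (within the scatter) is expected. Compound 4 is therefore estimated at 27%, between 12% and 42%.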

Compound 4, a percentage reported as inhibition, in the whole organism at one dose (the size of the read-out at that dose, not a potency): 29.8%
Estimate against measurement, compound 4: 2.8 percentage points below, and the stated range covers the measured number.
By their numbers in this assay, from the lowest: compounds 1, 2 and 4 (each within the scatter of the next); then compound 3.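

In this assay, the step of a number 6.2 percentage points higher from compound 2 to compound 4 (within the scatter) shows that hydroxy on the ethyl chain leaves the number within the scatter, and the step of a number 7.2 percentage points higher from compound 1 to compound 4 (within the scatter) keeps this chain with the dimethylamino amide. The step of a number 14.9 percentage points lower from compound 3 to compound 4 (beyond the scatter) sets compound 3 apart from this polar-free comparison of chains: among these amides, only the cyclohexyl compound stands beyond the scatter of the others. Nothing available gives a reason for these numbers. From the compounds shown here alone, it remains open whether a longer chain, a chain ending in an amine or a carboxylic acid, or a cyclopentyl ring would stay with the chains or come closer to compound 3.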